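Ethylsulfanyl for Ethoxy on a Fused Bicyclic Core

This account rests on a few compounds, and the source may have more. Where it says the series, first, only, none or still open, it means among the compounds named here.

Measured compounds:
compound 1 `CCOc1nn2cc(-c3cc4ccccc4o3)nc2s1`: 57%
compound 2 `COc1cc(OCc2cccc(C#N)c2)c2cc(-c3cn4nc(OC)sc4n3)oc2c1`: 100%

For the measured compounds named here, in an ADME assay on microsomes from liver (Homo sapiens) for metabolic stability, with a stated time of 10 min (a lower number here means that less of the compound is left, a higher number that more of the compound is left), compound 1 gives 57%, the lower of the two numbers known; compound 2 gives 100%, and the gap between the two lies beyond the scatter. Compound 3 `CCSc1nn2cc(-c3cc4ccccc4o3)nc2s1` has not been measured. It differs from compound 1 in one place: ethylsulfanyl in place of ethoxy on an aromatic carbon. Going by the values given here, no step between measured compounds separates this change on its own, so the size of the effect cannot be read from the data. The author expects a small step downward in this assay, a number 9 percentage points lower from compound 1 to compound 3 (within the scatter), possibly within the scatter. Compound 3 is therefore estimated at 48%, in a range from 28% to 70%.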

Compound 3, percent of the compound remaining: 45%
For compound 3 the middle estimate is 3 percentage points above the measured one, and the stated range covers the measured number.
By their numbers in this assay, from the lowest: compound 3; then compound 1; then compound 2.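

In this assay, for the compounds shown here, the exchange of ethoxy for ethylsulfanyl gives the first step that isolates a single change at this position, a number 12 percentage points lower from compound 1 to compound 3 (beyond the scatter), a modest step that lies beyond the scatter. The position is thus not indifferent to sulfur in place of oxygen, even though the heavy-atom count of the group stays the same. Nothing available explains the step. As far as these compounds go, whether an amine or a longer chain on this aromatic carbon would move the number further remains open, as does whether the same exchange would give a similar step in compound 2.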